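Benzyl swap from compound 3 to compound 4

The compounds below may be only part of what the source reports. "The series", "measured", "known", "first", "only" and "open" are said of these compounds alone.

In an ADME assay for permeability, using PAMPA, with a stated time of 30 min, at pH 7.4 (on this read-out higher numbers stand for higher permeability and lower numbers for lower permeability), compound 3 (`COc1cccc(CNCCCNc2ccnc3cc(-c4ccccc4)ccc23)c1O`) gives 237 10^-6 cm/s, within the scatter of compound 2 (`COc1ccc(Oc2ccc3c(NCCCNCc4cc(F)ccc4OC)ccnc3c2)cc1`) at 317 10^-6 cm/s. Compound 1 (`COc1ccc(F)cc1CNCCCNc1ccnc2cc(Cc3ccc(C#N)cc3)ccc12`) gives a much lower 23 10^-6 cm/s.

Compound 4 (`COc1ccc(F)cc1CNCCCNc1ccnc2cc(-c3ccccc3)ccc12`) differs from compound 3 by 5-fluoro-2-methoxyphenyl in place of 2-hydroxy-3-methoxyphenyl on a saturated chain carbon bound to an amine nitrogen. Compounds 1 and 2 both carry the incoming 5-fluoro-2-methoxybenzyl, yet their values differ widely. Among the measured compounds shown here, the only measured step, a 14-fold higher number from compound 1 to compound 2 (1.14 log units; beyond the scatter), is large, but it is a change on an aromatic carbon, and no measured step tests this benzyl swap. The expected step is a 1.1-fold higher number from compound 3 to compound 4 (0.02 log units; within the scatter), none beyond the scatter. For compound 4 the estimated value is 250 10^-6 cm/s, with an expected range of 110 10^-6 cm/s to 500 10^-6 cm/s.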

Compound 4, apparent permeability: 237 10^-6 cm/s
Compound 4: the middle estimate sits 1.1-fold (0.02 log units) above what was measured; measured number inside the range.
By their numbers in this assay, from the lowest: compound 1; then compounds 3, 4 and 2 (each within the scatter of the next).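

In this assay, the benzyl swap on a saturated chain carbon bound to an amine nitrogen now has a measured step (no change at the digits printed from compound 3 to compound 4 (within the scatter)), so 2-hydroxy-3-methoxyphenyl and 5-fluoro-2-methoxyphenyl are not told apart here, even though the hydrogen-bond donor of the leaving group is lost. With 5-fluoro-2-methoxybenzyl held constant, phenyl in place of 4-cyanobenzyl on an aromatic carbon gives a large step (a 10-fold higher number from compound 1 to compound 4 (1.01 log units; beyond the scatter)), whereas phenyl in place of 4-methoxyphenoxy does not (a 1.3-fold lower number from compound 2 to compound 4 (0.13 log units; within the scatter)).

As far as these compounds go, whether a carboxylic acid or an amine on the phenyl ring of this benzyl group would leave the number equally unchanged stays open. Nothing at hand accounts for these steps.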